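The source may hold more compounds than are shown below. What is called first, only, known or untested is meant among the compounds shown, and "the series" means these compounds.

Compound 1 `CC(C)=CCOc1ccc2c(c1)OC(c1ccc(F)cc1)CC2=O`: 7320 nM
Compound 2 `CC(C)=CCOc1cc(O)c2c(c1)OC(c1ccccc1F)CC2=O`: 5300 nM
Compound 3 `CC(C)=CCOc1cc(O)c2c(c1)OC(c1cccc(F)c1)CC2=O`: 7240 nM

All three were tested in a functional assay; on this read-out lower numbers stand for stronger inhibition and higher numbers for weaker inhibition. Compound 3, at 7240 nM, lies within the scatter of both compound 1 and compound 2, so it stands apart from neither. Compound 4 `CC(C)=CCOc1cc(O)c2c(c1)OC(c1ccc(F)cc1)CC2=O` is the next to be measured, and it differs from compound 3 as follows: 4-fluorophenyl in place of 3-fluorophenyl on a saturated ring carbon. In words, this is 4-fluorophenyl in place of 3-fluorophenyl on a saturated ring carbon.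

The closest measured change is a 1.4-fold higher number from compound 2 to compound 3 (0.14 log units; within the scatter). Compound 1 carries the same 4-fluorophenyl on a different core and gives 7320 nM. No real shift in either direction is therefore expected in this assay. The expected change is a 1.1-fold lower number from compound 3 to compound 4 (0.05 log units; within the scatter), which would stay within the scatter. For compound 4 the estimated value is 6500 nM, with an expected range of 3500 nM to 12000 nM.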

Compound 4, half-maximal inhibitory concentration: 6060 nM
The estimate for compound 4 lay 1.1-fold (0.03 log units) above the measured number, and the stated range covers the measured number.
By their numbers in this assay, from the lowest: compounds 2, 4, 3 and 1 (each within the scatter of the next).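

In this assay, the place of the fluorine on this phenyl ring makes no real difference (a 1.2-fold lower number from compound 3 to compound 4 (0.08 log units; within the scatter); a 1.1-fold higher number from compound 2 to compound 4 (0.06 log units; within the scatter)), so 2-fluorophenyl, 3-fluorophenyl and 4-fluorophenyl on this saturated ring carbon cannot be told apart. Hydroxy in place of hydrogen on an aromatic carbon also stays within the scatter (a 1.2-fold lower number from compound 1 to compound 4 (0.08 log units; within the scatter)). From the compounds shown here alone, whether an amine or a carboxylic acid in place of the fluorine would move the number remains open. No outside measurement bears on these small steps.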